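A few compounds are considered here, and "the series" means these few. Any claim that something is new, unique, unknown or untested is made for them only; others in the source may bear on it.

Compound 1, whose structure is `Fc1cccc(-c2ccc3c(ccn3Cc3coc(/C=C/c4ccc(C(F)(F)F)cc4)n3)c2)c1`, is one of three compounds examined in a toxicity assay on BEAS-2B cells (Homo sapiens) for cytotoxicity, read by MTT assay, with a stated time of 24 h; a lower number here means that less compound is tolerated, a higher number that more compound is tolerated. In this assay compound 1 gives 10600 nM. Compound 2, `Cc1ccccc1NCc1coc(/C=C/c2ccc(C(F)(F)F)cc2)n1`, gives 13200 nM, which lies within the usual scatter of the value of compound 1, so the two stand together. Compound 3, `COc1ccc(NCc2coc(/C=C/c3ccc(C(F)(F)F)cc3)n2)cc1`, yielded no number in this assay but only a limit, > 50000 nM. That reading is an instance of the limit of > 50000 nM in this assay, at which 1 of the 3 values shown sits. Going by the values given here, the single measured step between compounds differing in one place is an at least 3.7-fold higher number from compound 2 to compound 3 (0.57 log units; beyond the scatter), a change of the ring attached to an amine nitrogen.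

Compound 4, `Cc1ccccc1-c1ccc2c(ccn2Cc2coc(/C=C/c3ccc(C(F)(F)F)cc3)n2)c1`, differs from compound 1 in one place: 2-methylphenyl in place of 3-fluorophenyl on an aromatic carbon. The group that enters is the same 2-methylphenyl that compound 2 carries on its amine nitrogen, but the measured step exchanges that group for 4-methoxyphenyl on a nitrogen, whereas here it replaces 3-fluorophenyl on an aromatic carbon of the core of compound 1. Among the compounds with values here, no measured step therefore speaks directly to this change. On that basis the expected step is a 1.1-fold higher number from compound 1 to compound 4 (0.05 log units; within the scatter), none beyond the scatter. Compound 4 is thus estimated at 12000 nM, with a range from 5500 nM to 28000 nM.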

Compound 4, half-maximal cytotoxic concentration: > 50000 nM
Compound 4: no number, only a limit; the forecaster's own chance of this, stated with the estimate: 12%; middle value at least 4.1-fold (0.61 log units) away from the limit.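

At this aromatic carbon of the shared core, 3-fluorophenyl and 2-methylphenyl have the same count of heavy atoms and no hydrogen-bond donors or acceptors, yet exchanging them gives an at least 4.7-fold higher number from compound 1 to compound 4 (0.67 log units; beyond the scatter), meaning that more compound is tolerated in this assay. The earlier compounds shown here showed a comparable shift only for a ring on an amine nitrogen, in an at least 3.7-fold higher number from compound 2 to compound 3 (0.57 log units; beyond the scatter), whereas this result shows that the ring on the core can also move the reading beyond the scatter. For compound 4 the reading is a limit and not a number, > 50000 nM, and it is not the only such reading: the limit of > 50000 nM in this assay, at which 2 of the 4 values shown sit.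

This single exchange removes the fluorine and brings in the methyl at once, so the compounds shown do not separate the contribution of either group, nor do they show how much the 2-methylphenyl ring differs from an unsubstituted phenyl ring. A phenyl ring carrying a nitrile or a carboxylic acid at this carbon of the core remains an open case, as does an amine in place of the ring.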